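The source may report more compounds than this note shows. Statements on the series, on what has been measured and on what is new or still open speak of the compounds shown alone.

Of the compounds shown here, three sharing one core have been tested in a functional assay on HeLa cells (Homo sapiens) for antiproliferative activity, read by sulforhodamine B assay, with a stated time of 48 h; on this read-out lower numbers stand for stronger inhibition of growth and higher numbers for weaker inhibition of growth. Compound 1 `CCCCCCc1cn(CCCN2C(=O)COc3ccccc32)nn1` gives 100 nM. Compound 3 `CCCCc1cn(CCCN2C(=O)COc3ccccc32)nn1` gives 1020 nM, the highest of the two numbers; its nearest neighbour is compound 1, and the change hydrogen in place of ethyl on a saturated chain carbon brings a 10-fold higher number from compound 1 to compound 3 (1.01 log units; beyond the scatter). Compound 2 `O=C1COc2ccccc2N1CCCn1cc(-c2cccnc2)nn1` gives only a limit of the assay, > 100000 nM. the limit of > 100000 nM in this assay, at which 1 of the 3 values shown sits, is that limit.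

Compound 4 `O=C1COc2ccccc2N1CCCn1cc(C2(O)CCCCC2)nn1` is not yet measured; it differs from compound 3 by 1-hydroxycyclohexyl in place of butyl on an aromatic carbon. Going by the values given here, two measured steps bear on this change. Butyl in place of pyridin-3-yl on the same aromatic carbon gave an at least 98-fold lower number from compound 2 to compound 3 (1.99 log units; beyond the scatter), so a ring at this carbon has gone with a far higher number, while the chain shortening gave a 10-fold higher number from compound 1 to compound 3 (1.01 log units; beyond the scatter). Since compound 2 reached only a limit with a ring here, the 1-hydroxycyclohexyl of compound 4 is expected to raise the number, though perhaps not to a limit. The expected step is a 5.9-fold higher number from compound 3 to compound 4 (0.77 log units; beyond the scatter). Compound 4 is estimated at 6000 nM, within a range from 1000 nM to 60000 nM.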

Compound 4, concentration for 50% growth inhibition: 2000 nM
Compound 4: middle estimate off by 3.0-fold (0.48 log units), on the high side; measured number inside the range.
By their numbers in this assay, from the lowest: compound 1; then compounds 3 and 4 (each within the scatter of the next). At a limit, above all of these: compound 2.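

In this assay, 1-hydroxycyclohexyl on this aromatic carbon of the five-membered aromatic ring stands within the scatter of butyl, a 2.0-fold higher number from compound 3 to compound 4 (0.29 log units; within the scatter), so a ring at this carbon does not by itself go with the result seen for pyridin-3-yl. Against the pyridin-3-yl compound the step is an at least 50-fold lower number from compound 2 to compound 4 (1.69 log units; beyond the scatter), and it can be read only as a bound, as the value of compound 2 is a limit: the limit of > 100000 nM in this assay, at which 1 of the 4 values shown sits.

Hexyl stays apart from the new group, a 20-fold higher number from compound 1 to compound 4 (1.30 log units; beyond the scatter), so the hexyl compound keeps the lowest number of the four.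

The compounds shown leave open how far the hydroxyl and the carbon ring each count at this position, a question that a plain cyclohexyl group would address. They also leave open whether a chain longer than hexyl, such as octyl, would lower the number further.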